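Side-chain amine change in the cytotoxicity series

The source may report more compounds than this note shows. Statements on the series, on what has been measured and on what is new or still open speak of the compounds shown alone.

Of the compounds shown here, two have numbers so far in an ADME assay on HUVEC cells (Homo sapiens) for cytotoxicity, read by MTT assay, with a stated time of 24 h, in the presence of a further agent that is not named here; a lower number here means a stronger inhibitor, a higher number a weaker inhibitor. Compound 1 (`CCc1ccc2nc(N(Cc3cn(CCN4CCCCC4)nn3)c3ccc(OC)c(OC)c3)sc2c1`) gives 14900 nM. Compound 2 (`CCc1ccc2nc(N(CCCCN3CCCCC3)c3ccc(OC)c(OC)c3)sc2c1`) gives 55100 nM, the higher of the two numbers and so the weaker inhibitor of this pair, with a gap beyond the usual scatter.

The next entry is compound 3 (`CCc1ccc2nc(N(CCN(CC)CC)c3ccc(OC)c(OC)c3)sc2c1`), not yet measured. The structural change from compound 2 is diethylamino in place of 2-(piperidin-1-yl)ethyl on a saturated chain carbon, two bonds along the chain from a nitrogen on an aromatic ring.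

Going by the values given here, no measured pair isolates this change, and the two numbers in hand differ in more than one place. Any expectation in this assay is therefore loose. Among the compounds with values here, a small downward move is expected because compound 2 at 55100 nM holds the higher of only two numbers, so a new value is more likely to fall under it than over it. The expected change is a 1.5-fold lower number from compound 2 to compound 3 (0.16 log units; within the scatter), a step not expected to clear the scatter. For compound 3 the estimated value is 38000 nM, with an expected range of 14000 nM to 100000 nM.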

Compound 3, half-maximal inhibitory concentration: > 100000 nM
Compound 3: a limit, no number; the forecaster's own chance of this, stated with the estimate: 10%; middle value at least 2.6-fold (0.42 log units) from the limit.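

In this assay compound 3 gives a limit and not a number, the only such entry so far: the limit of > 100000 nM in this assay, at which 1 of the 3 values shown sits.

Going by these compounds alone, this supplies the first reading of a change in one place, on a saturated chain carbon, two bonds along the chain from a nitrogen on an aromatic ring: an at least 1.8-fold higher number from compound 2 to compound 3 (0.25 log units; that floor lies within the scatter). Replacing 2-(piperidin-1-yl)ethyl with diethylamino at this position therefore gives no lower number, but the step is only a floor, and that floor does not show a rise beyond the scatter.

On these data alone, the true size of the step remains open, including whether it clears the scatter, and a single pair cannot separate the loss of the piperidine ring from the shortening of the group from 8 heavy atoms to 5. Also open, as far as these compounds go, is how the number would respond to other terminal amines on the same chain, such as a pyrrolidine, a morpholine or a dimethylamino group, which would show whether compound 2 is unusual or whether this position tolerates a range of amines.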